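Bromophenyl analogue in the allyl series: an estimate

The source may report more compounds than this note shows. Statements on the series, on what has been measured and on what is new or still open speak of the compounds shown alone.

Measured so far:
- compound 1 `COc1ccccc1/C=c1/[nH]c(=O)/c(=C\c2cccc(Cl)c2Cl)[nH]c1=O` – "not active" (no number reported) in a functional assay on A549 cells (Homo sapiens) for cytotoxicity, read by CCK-8 assay, with a stated time of 72 h; on this read-out lower numbers stand for stronger inhibition and higher numbers for weaker inhibition
- compound 2 `C=CCn1c(=O)/c(=C\c2ccccc2Cl)[nH]c(=O)/c1=C\c1ccccc1OC` – 5300 nM
- compound 3 `C=CCn1c(=O)/c(=C\c2cccc(Cl)c2Cl)[nH]c(=O)/c1=C\c1ccccc1OC` – 2300 nM

Compound 3 gives the lowest number of the two reported values; compound 2 sits at a 2.3-fold lower number from compound 2 to compound 3 (0.36 log units; beyond the scatter), a modest step that comes with the chloro in place of hydrogen on an aromatic carbon. Compound 1 was reported without a number.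

Compound 4 `C=CCn1c(=O)/c(=C\c2cccc(Br)c2)[nH]c(=O)/c1=C\c1ccccc1OC` differs from compound 3 in 3-bromophenyl in place of 2,3-dichlorophenyl on a double-bonded chain carbon bound to an aromatic carbon. For the measured compounds named here, no measured step matches this change; the only step, from compound 2 to compound 3, shows that a second chloro gave a modest gain, and compound 4 loses that arrangement. Compound 4 is therefore expected to lie a 1.7-fold higher number from compound 3 to compound 4 (0.24 log units; within the scatter) in this assay. The estimate for compound 4 is 4000 nM, in the range 1500 nM to 12000 nM.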

Compound 4, half-maximal inhibitory concentration: 5400 nM
Compound 4: the middle estimate sits 1.4-fold (0.13 log units) below what was measured; the range from low to high includes it.
By their numbers in this assay, from the lowest: compound 3; then compounds 2 and 4 (each within the scatter of the next).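

In this assay, 3-bromophenyl in place of 2,3-dichlorophenyl on the double-bonded chain carbon gives a 2.3-fold higher number from compound 3 to compound 4 (0.37 log units; beyond the scatter), so this single bromine does not keep the advantage of the dichlorophenyl group. 3-Bromophenyl in place of 2-chlorophenyl at the same place gives a 1.0-fold higher number from compound 2 to compound 4 (0.01 log units; within the scatter), so these two groups cannot be told apart in this read-out.

As far as these compounds go, whether a phenyl carrying an amine or a carboxylic acid at this place would fit this order remains open. Nothing given here accounts for these steps.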